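The source may report more compounds than this note shows. Statements on the series, on what has been measured and on what is new or still open speak of the compounds shown alone.

In a functional assay on MCF7 cells (Homo sapiens) for antiproliferative activity, with a stated time of 5 days (on this read-out higher numbers stand for weaker inhibition and lower numbers for stronger inhibition), the measured compounds read as follows:
- compound 1 `COc1ccc(-c2[nH]c3ccc(F)cc3c2C=C(C#N)C#N)cc1` gives 310 nM
- compound 2 `CCCc1ccc2[nH]c(-c3ccc(OC)cc3)c(C=C(C#N)C#N)c2c1` gives 190 nM
- compound 3 `CCCCCc1ccc2[nH]c(-c3ccc(OC)cc3)c(C=C(C#N)C#N)c2c1` gives 76 nM

Compound 3 stands lowest of the three and is the most potent so far. Compound 4 `CCCCCCc1ccc2[nH]c(-c3ccc(OC)cc3)c(C=C(C#N)C#N)c2c1` alters the pentyl chain of compound 3 in one place: methyl in place of hydrogen on a saturated chain carbon, five bonds along the chain from an aromatic carbon that is, methyl in place of hydrogen on a saturated chain carbon, five bonds along the chain from an aromatic carbon. The closest guide is a 2.5-fold lower number from compound 2 to compound 3 (0.40 log units; beyond the scatter) where ethyl replaced hydrogen on the same chain. The wider comparison shows a 4.1-fold lower number from compound 1 to compound 3 (0.61 log units; beyond the scatter) while a 1.6-fold lower number from compound 1 to compound 2 (0.21 log units; within the scatter) stays small. Methyl is a smaller addition than ethyl, so a smaller step in the same direction is expected, though nothing measured shows whether the trend continues beyond pentyl. The expected change is a 1.3-fold lower number from compound 3 to compound 4 (0.10 log units; within the scatter) and would not clear the scatter. Compound 4 is estimated at 60 nM with an expected range from 25 nM to 140 nM.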

Compound 4, half-maximal inhibitory concentration: 25 nM
The estimate for compound 4 lay 2.4-fold (0.38 log units) above the measured number, and the stated range covers the measured number.
By their numbers in this assay, from the lowest: compound 4; then compound 3; then compounds 2 and 1 (each within the scatter of the next).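

In this assay, one more methyl at the end of the chain still gives a 3.0-fold lower number from compound 3 to compound 4 (0.48 log units; beyond the scatter), so the gain does not stop at pentyl, and hexyl gives the lowest number of the four. The longer chain adds up to a 7.6-fold lower number from compound 2 to compound 4 (0.88 log units; beyond the scatter), and replacing fluoro with hexyl gives a 12-fold lower number from compound 1 to compound 4 (1.09 log units; beyond the scatter). Nothing available explains why the hexyl chain does better. As far as these compounds go, whether a heptyl or longer chain lowers the number further remains open, as does how a branched chain or a chain ending in an amine would compare.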